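A few compounds are considered here, and "the series" means these few. Any claim that something is new, unique, unknown or untested is made for them only; others in the source may bear on it.

Compound 1 `CN(C(=O)c1ccccc1)c1ccc2[nH]c(-c3n[nH]c4ccccc34)cc2n1` gives 4850 nM in a functional assay on HL-60 cells (Homo sapiens) for antiproliferative activity, read by MTT assay, with a stated time of 72 h (a higher number here means a weaker inhibitor, a lower number a stronger inhibitor), and compound 2 `CN(C(=O)c1ccccc1)c1ccc2[nH]c(-c3n[nH]c4cc(Cl)ccc34)cc2n1` gives 5620 nM; these two numbers sit within the scatter of each other, the step of a 1.2-fold higher number from compound 1 to compound 2 (0.06 log units; within the scatter) being the only measured one. Compound 3 `COc1ccc(NC(=O)N(C)c2ccc3[nH]c(-c4n[nH]c5ccccc45)cc3n2)cc1` differs from compound 1 by (4-methoxyphenyl)amino in place of phenyl on a carbonyl carbon. The measured step concerns a chloro on an aromatic carbon, not the carbonyl carbon, so it offers no guide to this change, and nothing here predicts a shift in this assay beyond the scatter. Relative to compound 1, compound 3 is expected to show a step of a 1.0-fold higher number from compound 1 to compound 3 (0.01 log units; within the scatter). Compound 3 is therefore estimated at 5000 nM, within a range from 1500 nM to 16000 nM.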

Compound 3, half-maximal inhibitory concentration: 7.9 nM
The estimate for compound 3 lay 630-fold (2.80 log units) above the measured number, outside the stated range (below it).
By their numbers in this assay, from the lowest: compound 3; then compounds 1 and 2 (each within the scatter of the next).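

In this assay, the carbonyl carbon proves to be a highly sensitive position: (4-methoxyphenyl)amino in place of phenyl gives a 610-fold lower number from compound 1 to compound 3 (2.79 log units; beyond the scatter), whereas the earlier step, a chloro on an aromatic carbon, stayed within the scatter. The entering group brings a hydrogen-bond donor and a hydrogen-bond acceptor that phenyl lacks, but no measurement here connects either one to the size of this step. No evidence is available on why the number falls so far.

On these data alone, it remains open whether the amino link or the methoxy group matters more. Plain phenylamino, without the methoxy, or benzylamino, with a carbon added to the link, would help separate the two.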